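The compounds below may be only part of what the source reports. "The series", "measured", "known", "first", "only" and "open" are said of these compounds alone.

Measured so far:
compound 1 `O=C(/C=C\Nc1ccc(C(F)(F)F)cc1)c1cn(-c2ccccc2)nc1-c1ccc(F)cc1` — > 50000 nM
compound 2 `O=C(/C=C\Nc1ccc(O)cc1)c1cn(-c2ccccc2)nc1-c1ccc(F)cc1` — 1500 nM
compound 3 `O=C(/C=C\Nc1ccc(C(F)(F)F)cc1)c1cn(-c2ccccc2)nc1-c1ccc(Cl)cc1` — > 50000 nM

In a functional assay on A549 cells (Homo sapiens) for antiproliferative activity, read by MTT assay, with a stated time of 48 h (a lower number here means a stronger inhibitor, a higher number a weaker inhibitor), the value of compound 1 is a limit, not a number. The value of compound 3 is also a limit. Compound 2 gives a number. The change hydroxy in place of trifluoromethyl on an aromatic carbon brought an at least 33-fold lower number from compound 1 to compound 2 (1.52 log units; beyond the scatter). The cores of compound 1 and compound 3 differ by chloro in place of fluoro on an aromatic carbon; that step is a step that the two limits leave unreadable from compound 1 to compound 3, because of the limit of > 50000 nM in this assay, at which 2 of the 3 values shown sit.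

Compound 4 `O=C(/C=C\Nc1ccc(O)cc1)c1cn(-c2ccccc2)nc1-c1ccc(Cl)cc1` has not been measured. It arises from compound 3 by hydroxy in place of trifluoromethyl on an aromatic carbon, the same change as from compound 1 to compound 2. In this assay the expected step is an at least 25-fold lower number from compound 3 to compound 4 (1.39 log units; beyond the scatter), resting on an at least 33-fold lower number from compound 1 to compound 2 (1.52 log units; beyond the scatter), though the core of compound 3 gives no measured number to build on. The estimate for compound 4 is 2000 nM, between 500 nM and 10000 nM.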

Compound 4, half-maximal inhibitory concentration: 1910 nM
Estimate against measurement, compound 4: 1.0-fold (0.02 log units) above; low and high end bracket the measured number.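

In this assay, hydroxy in place of trifluoromethyl on the core of compound 3 brought an at least 26-fold lower number from compound 3 to compound 4 (1.41 log units; beyond the scatter), a large step in the same direction as the one seen on the core of compound 1. With hydroxy in place, chloro in place of fluoro gives a 1.3-fold higher number from compound 2 to compound 4 (0.10 log units; within the scatter), while the same exchange between compound 1 and compound 3 cannot be read, as both values are limits. So the direction of the change carries over between these two cores, but equal size on both is not shown: the same change on two cores in this assay, an at least 33-fold lower number (1.52 log units; beyond the scatter) from compound 1 to compound 2 and an at least 26-fold lower number (1.41 log units; beyond the scatter) from compound 3 to compound 4; the limit leaves it open whether they differ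

The compounds shown carry only trifluoromethyl or hydroxy at this place, so it stays open how an amine, a methoxy group or a carboxylic acid there would read. From the compounds shown here alone, it also stays open whether the step would hold with bromo in place of fluoro or chloro.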